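Chloro for Fluoro on a Phenyl-Bearing Core

A few compounds are considered here, and "the series" means these few. Any claim that something is new, unique, unknown or untested is made for them only; others in the source may bear on it.

Four related compounds share a core and differ in two spots. Compound 1 `Cc1nc2ccccc2c(=O)n1/N=C/c1ccc(Oc2ccc(Cl)cc2)cc1` and compound 2 `Cc1nc2ccccc2c(=O)n1/N=C/c1ccc(Oc2ccc(F)cc2)cc1` carry a methyl on the core, while compound 3 `O=c1c2ccccc2nc(-c2ccccc2)n1/N=C/c1ccc(Oc2ccc(F)cc2)cc1` and the unmeasured compound 4 `O=c1c2ccccc2nc(-c2ccccc2)n1/N=C/c1ccc(Oc2ccc(Cl)cc2)cc1` carry a phenyl there; the two cores differ by phenyl in place of methyl on an aromatic carbon, a change that produced a number 2.00 log units higher from compound 2 to compound 3 (beyond the scatter). In a physicochemical assay for lipophilicity, in phosphate buffer, measured as octanol-water partition (on this read-out higher numbers stand for higher lipophilicity and lower numbers for lower lipophilicity), compound 2 gives 4.21, compound 1 gives 4.6 and compound 3 gives 6.21, the highest of the three measured numbers. The change from compound 2 to compound 1 is chloro in place of fluoro on an aromatic carbon and produced a number 0.39 log units higher from compound 2 to compound 1 (beyond the scatter). The change from compound 3 to compound 4 is chloro in place of fluoro on an aromatic carbon, the same change, here made on the phenyl-bearing core. A step of a number 0.39 log units higher from compound 3 to compound 4 (beyond the scatter) is expected in this assay, the same size as a number 0.39 log units higher from compound 2 to compound 1 (beyond the scatter), on the ground that the same exchange made that earlier step. Starting from compound 3 at 6.21, compound 4 is estimated to reach 6.6 in this assay, most likely between 6.2 and 7.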

Compound 4, partition coefficient: 6.38
Compound 4: the middle estimate sits 0.22 log units above what was measured; the measured number falls inside the stated range.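

On the phenyl-bearing core, chloro in place of fluoro gives a number 0.17 log units higher from compound 3 to compound 4 (within the scatter) in this assay, whereas on the methyl-bearing core the same exchange gave a number 0.39 log units higher from compound 2 to compound 1 (beyond the scatter), so a step that stood clear of measurement noise on one core does not stand clear on the other. Phenyl in place of methyl behaves alike with either halogen, giving a number 1.78 log units higher from compound 1 to compound 4 (beyond the scatter) with chloro present and a number 2.00 log units higher from compound 2 to compound 3 (beyond the scatter) with fluoro present. Within the data shown here, these four compounds show only this one pair of cores, so they do not establish that the exchange truly differs in size between the cores, and nothing measured here speaks to a cause.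

The compounds shown leave open how a bromo or a methoxy group would read in place of the chloro on the 4-chlorophenoxy group. They also leave open whether the chloro-for-fluoro exchange would stand clear of the scatter on a core carrying an amine or a longer chain where compound 1 has its methyl.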